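The compounds below may be only part of what the source reports. "The series", "measured", "known", "first", "only" and "open" are said of these compounds alone.

Measured so far:
- compound 1, `COC(=O)c1ccc(N(Cc2cnc(C3CCCCC3)cn2)C(=O)[C@H]2CCN2S(=O)(=O)c2c(F)c(F)c(F)c(F)c2F)c(F)c1`: 4000 nM
- compound 2, `O=C(NO)c1ccc(N(Cc2ccc(C3CCCCC3)cc2)C(=O)[C@H]2CCN2S(=O)(=O)c2c(F)c(F)c(F)c(F)c2F)cc1O`: 7500 nM
- compound 3, `CNC(=O)c1ccc(N(Cc2ccc(C3CCCCC3)cn2)C(=O)[C@H]2CCN2S(=O)(=O)c2c(F)c(F)c(F)c(F)c2F)c(F)c1`: "not determined" (no result reported)

The study is built around a shared core carrying a pentafluorophenyl sulfonamide on an azetidine and an amide whose nitrogen bears a cyclohexyl-substituted benzylic or heteroaromatic arm. In an ADME assay on MCF-10A cells (Homo sapiens) for cytotoxicity, with a stated time of 72 h (a lower number here means that less compound is needed, a higher number that more compound is needed for the effect), compound 1 gives 4000 nM, and compound 2 gives 7500 nM. The two numbers are close: the gap between compound 1 and compound 2 lies within the scatter of this measurement, so neither can be set apart from the other. Within the data shown here, compound 3 has no result in this assay, so only two numbers are available.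

Compound 4, `O=C([C@H]1CCN1S(=O)(=O)c1c(F)c(F)c(F)c(F)c1F)N(Cc1cnc(C2CCCCC2)cn1)c1cc2[nH]ncc2cc1F`, differs from compound 1 in one place: 5-fluoro-1H-indazol-6-yl in place of 2-fluoro-4-(methoxycarbonyl)phenyl on an amide-type nitrogen. Among the measured compounds shown here, no measured pair isolates such a change, so there is no direct precedent to lean on. With both measured numbers sitting in the same region, the expectation for compound 4 is a step of modest size, in no direction beyond the scatter, so that a 1.1-fold higher number from compound 1 to compound 4 (0.05 log units; within the scatter) is expected to fall within the usual spread. Compound 4 is therefore estimated at 4500 nM in this assay, with a range from 1500 nM to 15000 nM.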

Compound 4, half-maximal effective concentration: 3200 nM
Beside the measured number, compound 4's estimate is 1.4-fold (0.15 log units) above it; the measured number falls inside the stated range.
By their numbers in this assay, from the lowest: compounds 4, 1 and 2 (each within the scatter of the next, the first and the last beyond it).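

In this assay, the exchange of 2-fluoro-4-(methoxycarbonyl)phenyl for 5-fluoro-1H-indazol-6-yl on the amide-type nitrogen gives a 1.3-fold lower number from compound 1 to compound 4 (0.10 log units; within the scatter), so replacing this group with one built quite differently, with a five-membered aromatic ring holding 2 hetero atoms and without the methoxycarbonyl group, leaves the number indistinguishable from that of compound 1. Among these compounds, the earlier compounds differ from one another in more than one place, so this pair is the first to isolate this position, and it shows that the number in this assay does not depend on the methoxycarbonyl group being present on this nitrogen substituent. Nothing available explains why the two groups read alike.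

The compounds shown leave open whether a group of another kind in this place, such as a carboxylic acid or an amine, would move the number in this assay beyond the scatter. They also leave open whether 5-fluoro-1H-indazol-6-yl would read the same with a different arm on the saturated chain carbon of that nitrogen.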